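This account rests on a few compounds, and the source may have more. Where it says the series, first, only, none or still open, it means among the compounds named here.

Measured compounds:

Compound 1, `CCOC(=O)[C@H](CCC(=O)O)NC(=O)c1ccc(CNc2nc3cc(N)cc(N)c3nc2-c2ccccc2)cc1`. In a functional assay on SNB-75 cells (Homo sapiens) for inhibition, read by sulforhodamine B assay, with a stated time of 48 h (a higher number here means that more compound is tolerated, a lower number that less compound is tolerated), compound 1 gives < 100000 nM, which is a limit of the assay rather than a number.

Compound 2, `COc1ccc(CNc2nc3cc(N)cc(N)c3nc2-c2ccccc2)cc1OC`. In this assay compound 2 gives 97700 nM.

Compound 3, `CCOC(=O)[C@H](CCC(=O)O)NC(=O)c1ccc(Sc2nc3cc(N)cc(N)c3nc2-c2ccccc2)cc1`. In this assay compound 3 gives < 100000 nM, again a limit of the assay and not a number.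

Going by the values given here, compound 2 thus stands as the only compound among the three with an actual number in this assay, and that number sits close to the limit of < 100000 nM in this assay, at which 2 of the 3 values shown sit. All three compounds share the same core; they differ in the group hung on the amine or sulfur link at its side.

Compound 4, `COc1cc(CNc2nc3cc(N)cc(N)c3nc2-c2ccccc2)cc(OC)c1OC`, has not yet been measured in this assay. It keeps the whole of compound 2 and differs in one place: methoxy in place of hydrogen on an aromatic carbon. Among the compounds with values here, no pair of measured compounds shows what such a change does here, so no measured step can guide the expectation. Given that compound 2 already lies at the weak end of this assay, the expected step is a 1.1-fold lower number from compound 2 to compound 4 (0.04 log units; within the scatter), that is, none beyond the usual scatter. Compound 4 is accordingly estimated at 90000 nM, with a range from 40000 nM to 200000 nM, and it may well come back only as a limit.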

Compound 4, concentration lethal to 50% of the cells: < 50200 nM
Compound 4: only a limit was reported; the forecaster's own chance of this, stated with the estimate: 50%; middle value at least 1.7-fold (0.25 log units) from the limit.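

In this assay compound 4 gives < 50200 nM, which is a limit of the assay and not a number. Going by these compounds, this gives the first view of what methoxy in place of hydrogen does on this aromatic carbon, ortho to one methoxy group and meta to another, and the reading is an at least 1.9-fold lower number from compound 2 to compound 4 (0.28 log units; that floor lies within the scatter); only the floor of the step is known, so its true size stays open, and the third methoxy group may have changed the number by little or by much. The limit of compound 4 also stands apart from the limit shared by the other two compounds that gave no number: the limit of < 50200 nM in this assay, at which 1 of the 4 values shown sits.

The compounds shown leave open whether a different group on this same carbon, such as a hydroxyl, an amine, a carboxylic acid or a longer chain like ethoxy, would move the number in either direction. They also leave open whether methoxy would have a similar effect on the differently built side groups of compound 1 and compound 3, and an exact value for compound 4 would be needed to fix the size of this step.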